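This account rests on a few compounds, and the source may have more. Where it says the series, first, only, none or still open, it means among the compounds named here.

Compound 1 `Nc1cccc(CNc2cc(C(F)(F)F)cc3[nH]ncc23)c1` gives 68% in an assay for inhibition of Tryptophan 2,3-dioxygenase (Homo sapiens), with stated times of 10 min and 60 min, tested at 10 uM; on this read-out lower numbers stand for a weaker effect and higher numbers for a stronger effect at the one concentration tested.
Compound 2 `CC(C)n1ncc2c(NCc3ccccc3[N+](=O)[O-])cc(C(F)(F)F)cc21` gives 35% in this assay.
Compound 3 `Cc1ccc(CNc2cc(C(F)(F)F)cc3[nH]ncc23)c([N+](=O)O)c1` gives 90% in this assay.

Among these three results in this assay, compound 1 stands second highest. Its nearest neighbour is compound 3, whose number is higher by a margin beyond the scatter, while compound 2 lies furthest away with a number lower than compound 1, again beyond the scatter. No two of these compounds differ in only one place, so no single step between measured compounds can be read from them; what they show is simply the spread of values across the set.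

Compound 4 `FC(F)(F)c1cc(NCc2cccc(Br)c2)c2cn[nH]c2c1` differs from compound 1 in a single place: bromo in place of amino on an aromatic carbon. Nothing measured here speaks directly to that exchange. Going by the values given here, since no comparable step is available, the step from compound 1 to compound 4 is expected to stay within the usual scatter, no change at the digits printed from compound 1 to compound 4 (within the scatter), with no clear direction. Compound 4 is therefore estimated at 68%, within a range from 45% to 88%.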

Compound 4, a percentage reported as inhibition, at one concentration (the size of the read-out at that concentration, not a potency): 67%
For compound 4 the middle estimate is 1 percentage points above the measured one; measured number inside the range.
By their numbers in this assay, from the lowest: compound 2; then compounds 4 and 1 (each within the scatter of the next); then compound 3.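

In this assay, going by these compounds alone, bromo in place of amino on an aromatic carbon gives a number 1 percentage points lower from compound 1 to compound 4 (within the scatter), the first step in the set that can be read at a single place. At this position of the six-membered aromatic ring, the read-out at the one concentration tested therefore does not separate the two groups, even though the hydrogen-bond donor and acceptor counted for amino leave with it and bromo brings neither. No evidence is available that bears on why these two groups give such similar numbers.

From the compounds shown here alone, whether a carboxylic acid, a nitrile or a methoxy group at the same place would also stay within the scatter remains open. So does whether bromo and amino would still match when tested over a range of concentrations, since a single-concentration figure is not a potency.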